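This account rests on a few compounds, and the source may have more. Where it says the series, first, only, none or still open, it means among the compounds named here.

Measured in a functional assay on HeLa cells (Homo sapiens) for inhibition, read by CCK-8 assay, with a stated time of 72 h, tested at 8 uM; on this read-out lower numbers stand for less inhibition of growth and higher numbers for more inhibition of growth at the one concentration tested:
compound 1 `Nc1ccccc1NC(=O)/C=C/c1ccc(CSc2ccc(Cl)cc2)cc1` gives 17.3%
compound 2 `CCc1ccc(SCc2ccc(C(=O)Nc3ccccc3N)cc2)cc1` gives 71%
compound 3 `Cc1ccc(SCc2ccc(C(=O)Nc3ccccc3N)cc2)cc1` gives 79.2%

Compound 1 has the lowest number of the three. Its value sits well below those of compound 2 and compound 3, and both gaps lie beyond the usual scatter of such measurements. Those two compounds also differ from compound 1 in more than one place, so the gaps cannot be tied to any single structural feature.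

The next compound is compound 4 `Nc1ccccc1NC(=O)/C=C/c1ccc(CSc2cccc3ccccc23)cc1`, which keeps the core of compound 1 and changes one group: naphthalen-1-yl in place of 4-chlorophenyl on a sulfur. In other words, naphthalen-1-yl stands in place of 4-chlorophenyl on a sulfur, so one aromatic ring becomes two.

Within the data shown here, only one measured step exists, a number 8.2 percentage points higher from compound 2 to compound 3 (within the scatter), and it stays within the scatter. Among the measured compounds shown here, it is a different change on a different parent, so it is only a weak guide, and no measured step tests this swap directly. With no evidence for a shift, no step beyond the scatter is expected in this assay, although the uncertainty is wide, more so upward.

The expected change is a number 2.7 percentage points higher from compound 1 to compound 4 (within the scatter).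

For compound 4 the estimate is 20%, with an expected range from 5% to 48%.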

Compound 4, percent growth inhibition at one concentration: 22.1%
Estimate against measurement, compound 4: 2.1 percentage points below, within the range that was stated.
By their numbers in this assay, from the lowest: compounds 1 and 4 (each within the scatter of the next); then compounds 2 and 3 (each within the scatter of the next).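

Within this assay the swap of 4-chlorophenyl for naphthalen-1-yl on a sulfur gives a number 4.8 percentage points higher from compound 1 to compound 4 (within the scatter) and is the only measured change at this place on the core of compound 1. The entering group brings 10 heavy atoms in place of 7, loses the chlorine and adds a second six-membered aromatic ring of carbon only, yet the read-out does not move beyond the usual scatter, so this larger all-carbon group can stand here with no measurable shift. Nothing on hand explains why these two groups read alike.

The compounds shown leave open whether a group of another kind on the sulfur, such as a plain butyl chain or a phenyl ring carrying an amine or a carboxylic acid, would move the number beyond the scatter. Going by these compounds, it also stays open whether naphthalen-1-yl would read the same on the core of compound 3, which gives 79.2% in this assay with its own group on the sulfur.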